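The source may hold more compounds than are shown below. What is called first, only, known or untested is meant among the compounds shown, and "the series" means these compounds.

Measured so far in an ADME assay on HepG2 cells (Homo sapiens) for cytotoxicity, read by luminescence, with a stated time of 72 h; a higher number here means that more compound is needed for the effect, a lower number that less compound is needed:

Compound 1 `C=Cc1cccc(-c2[nH]c3cc(OC)ccc3c(=O)c2C(=O)OCC)c1` gives > 21500 nM, a limit of the assay rather than a number.
Compound 2 `CCOC(=O)c1c(-c2cccc(OCC)c2)[nH]c2cc(OC)ccc2c1=O` gives > 21500 nM, again only a limit.
Compound 3 `CCOC(=O)c1c(-c2cccc(Oc3ccccc3)c2)[nH]c2cc(OC)ccc2c1=O` gives > 21500 nM, again only a limit.

Compound 1 therefore has no measured position in this assay beyond its limit, and the two further values shown are limits as well, as the limit of > 21500 nM in this assay, at which 3 of the 3 values shown sit, records. The compound still to be measured is compound 4 `CCOC(=O)c1c(-c2cccc(F)c2)[nH]c2cc(OC)ccc2c1=O`. It differs from compound 1 in one place, (fluoro in place of vinyl on an aromatic carbon). Going by the values given here, two measured steps touch the same place on the shared core: a step that the two limits leave unreadable from compound 1 to compound 2 and a step that the two limits leave unreadable from compound 1 to compound 3, but both run between limits, so neither has a readable size or direction. Nothing measured here shows that a change at this position moves the read-out at all, and nothing shows that it does not. With every value sitting at the same limit, the expectation for compound 4 is simply another limit, and the step that the limit leaves unreadable from compound 1 to compound 4 is estimated to be no step beyond the scatter. Compound 4 is thus expected to give about 30000 nM, with a range from 12000 nM to 80000 nM.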

Compound 4, half-maximal effective concentration: > 21500 nM
Compound 4: a limit, no number; the forecaster's own chance of this, stated with the estimate: 85%; the middle value is on the limit's open side.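

Going by these compounds alone, compound 4 in this assay also gives only a limit, so no step linking it to compound 1, compound 2 or compound 3 can be read, because all four compounds sit at the same point: the limit of > 21500 nM in this assay, at which 4 of the 4 values shown sit.

The compounds shown leave open whether any change at this place on the aromatic ring moves the read-out at all.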